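Taking the phenyl off compound 1

A few compounds are considered here, and "the series" means these few. Any claim that something is new, unique, unknown or untested is made for them only; others in the source may bear on it.

Compound 1 (`O=C1CS/C(=N/Nc2nncc3ccccc23)N1c1ccccc1`): 97 nM
Compound 2 (`O=S(=O)(Nc1ncccn1)c1ccc(Nc2nncc3ccccc23)cc1`): 45 nM
Compound 3 (`Clc1ccc(C(/C=C/c2ccccc2)=N\Nc2nncc3ccccc23)cc1`): 4.6 nM

All three numbers come from a functional assay on DU-145 cells (Homo sapiens) for antiproliferative activity, read by sulforhodamine B assay, with a stated time of 72 h (a lower number here means a stronger inhibitor, a higher number a weaker inhibitor), and show how much of each compound is needed to hold back cell growth by half. Compound 1 has the highest number of the three, so it is the weakest inhibitor in this small set. Compound 2 and compound 3 both lie lower, each by more than the usual scatter. No two of these compounds differ in only one place, so the set gives no direct measure of any single change.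

The next compound, compound 4 (`O=C1CS/C(=N/Nc2nncc3ccccc23)N1`), keeps the core of compound 1 but has hydrogen in place of phenyl on an amide-type nitrogen in a ring. All three measured compounds, including compound 1 at 97 nM in this assay, carry an aromatic ring outside the shared core, and compound 4 would be the first without one. That is thin evidence, but it points towards a weaker result, and the expected change is a 3.1-fold higher number from compound 1 to compound 4 (0.49 log units; beyond the scatter) in this assay, a moderate step with wide uncertainty. The estimate for compound 4 is 300 nM (expected range 70 nM to 1500 nM).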

Compound 4, half-maximal inhibitory concentration: 67 nM
For compound 4 the middle estimate is 4.5-fold (0.65 log units) above the measured one, and the stated range ends above it.
By their numbers in this assay, from the lowest: compound 3; then compounds 2, 4 and 1 (each within the scatter of the next, the first and the last beyond it).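

Putting hydrogen in place of phenyl on the amide-type nitrogen in the ring gives a 1.4-fold lower number from compound 1 to compound 4 (0.16 log units; within the scatter) in this assay, a step too small to count as a real difference in either direction. At this position, then, a whole six-membered aromatic ring can go without any measurable effect on the antiproliferative read-out, and compound 4 shows that an aromatic ring outside the shared core is not needed for activity in this series. No supporting measurement is available to explain why the two compounds read alike, so the result describes what happens at this position without saying why.

Only phenyl and hydrogen are shown on this nitrogen, two very different groups that give matching numbers, and that pair cannot reveal whether anything placed there could move the number beyond the scatter. A small methyl group, a longer chain such as butyl, or a chain ending in an amine or a carboxylic acid could each test whether this position truly tolerates change or whether these two groups simply happen to match.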